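Aryl ester variation in a urotensin-2 receptor series

This account rests on a few compounds, and the source may have more. Where it says the series, first, only, none or still open, it means among the compounds named here.

Measured in an assay on NIH3T3 cells with Urotensin-2 receptor (Homo sapiens) as the target; on this read-out higher numbers stand for an effect only at larger amounts of compound and lower numbers for an effect already at smaller amounts:
compound 1 `Cc1ccccc1C(=O)OC(CCN(C)C)c1ccc(Cl)cc1`: 1700 nM
compound 2 `CN(C)CCC(OC(=O)c1ccc2ccccc2c1)c1ccc(Cl)cc1`: 2090 nM
compound 3 `Cc1ccc(C(=O)OC(CCN(C)C)c2ccc(Cl)cc2)cc1`: 2750 nM

Within the data shown here, compound 1 has the lowest of the three numbers, but compound 2 and compound 3 both lie within the scatter of it; the single one-point step on record, a 1.6-fold higher number from compound 1 to compound 3 (0.21 log units; within the scatter), did not leave the scatter. Compound 4 `Cc1cc(Br)ccc1C(=O)OC(CCN(C)C)c1ccc(Cl)cc1` is compound 1 with the change (bromo in place of hydrogen on an aromatic carbon). Among the measured compounds shown here, no measured pair brings a bromo onto this ring, so the only bearing evidence is the indifference of this assay to repositioning the methyl (compound 1 to compound 3) and to the larger aryl of compound 2. Accordingly a step of a 1.1-fold lower number from compound 1 to compound 4 (0.05 log units; within the scatter) is expected, nothing beyond the scatter. Compound 4 is estimated at 1500 nM, range 600 nM to 4000 nM.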

Compound 4, half-maximal effective concentration: 1070 nM
The estimate for compound 4 lay 1.4-fold (0.15 log units) above the measured number, within the range that was stated.
By their numbers in this assay, from the lowest: compounds 4, 1, 2 and 3 (each within the scatter of the next, the first and the last beyond it).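

In this assay the position para to a large group accepts bromo, with a 1.6-fold lower number from compound 1 to compound 4 (0.20 log units; within the scatter) and the number staying within the scatter. Among these compounds, the 4-bromo-2-methylphenyl group in place of 4-methylphenyl gives a 2.6-fold lower number from compound 3 to compound 4 (0.41 log units; beyond the scatter) and is the only step here beyond the scatter, so this ring can separate compounds even though moving the methyl alone did not. No evidence on hand accounts for either step.

On these data alone, what an amine or a carboxylic acid would do at this position remains open. So does whether bromo would give the same step without the methyl group.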